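Removing the acetamido group from compound 1

The source may report more compounds than this note shows. Statements on the series, on what has been measured and on what is new or still open speak of the compounds shown alone.

- compound 1 `COc1ccc(/C=C/C(=O)c2ccc(NC(C)=O)c(-c3ccc(F)cc3)c2)cc1OC` gives 5630 nM in a functional assay on HepG2 cells (Homo sapiens) for cytotoxicity, read by sulforhodamine B assay, with a stated time of 48 h; a higher number here means a weaker inhibitor, a lower number a stronger inhibitor
- compound 2 `O=C(/C=C/c1ccc(Br)cc1)c1cccc(-c2cccc(F)c2)c1` gives 9920 nM in this assay
- compound 3 `O=C(/C=C/c1ccc(Cl)cc1)c1cccc(-c2cccc(F)c2)c1` gives 10400 nM in this assay

Compound 1 lies within the scatter of both compound 2 and compound 3, so the three values form one group and compound 1 holds no separate place in it. The next compound to read is compound 4 `COc1ccc(/C=C/C(=O)c2cccc(-c3ccc(F)cc3)c2)cc1OC`, not yet measured. It differs from compound 1 by hydrogen in place of acetamido on an aromatic carbon (hydrogen in place of acetamido on an aromatic carbon, ortho to a 4-fluorophenyl group). Among the measured compounds shown here, the one measured step (a 1.0-fold higher number from compound 2 to compound 3 (0.02 log units; within the scatter)) is chloro in place of bromo on an aromatic carbon and does not involve the acetamido group, so no measured step speaks directly to this change. Indirect guidance comes from compound 2 (9920 nM) and compound 3 (10400 nM), which carry no acetamido group but also differ from compound 4 elsewhere. A small shift towards a higher number is therefore expected, with nothing clearly beyond the scatter. The estimated step is a 1.5-fold higher number from compound 1 to compound 4 (0.18 log units; within the scatter) on this reading. In this assay the expected value for compound 4 is 8500 nM (estimated range 3500 nM to 20000 nM).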

Compound 4, half-maximal inhibitory concentration: 5370 nM
Beside the measured number, compound 4's estimate is 1.6-fold (0.20 log units) above it; the range from low to high includes it.
By their numbers in this assay, from the lowest: compounds 4, 1, 2 and 3 (each within the scatter of the next).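

Among the compounds shown here, exchanging acetamido for hydrogen on this aromatic carbon, ortho to a 4-fluorophenyl group, gives a 1.0-fold lower number from compound 1 to compound 4 (0.02 log units; within the scatter) in this assay, the first direct reading at this position. The acetamido group, with its 4 heavy atoms, its hydrogen-bond donor and its hydrogen-bond acceptor, can therefore leave the core of compound 1 with no step beyond the scatter, so this cytotoxicity reading does not depend on that group in this one matched pair. No measurement at hand gives a reason for this reading.

As far as these compounds go, the pair compares only hydrogen and acetamido, so it remains open whether an amine, a carboxylic acid or a longer amide chain on the same carbon would read apart from compound 1 and compound 4. Compound 2 and compound 3 differ from compound 4 in more than one place, which leaves the separate contributions of the two methoxy groups and of the fluorine position on the outer aryl ring unresolved on this core.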